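The source may hold more compounds than are shown below. What is called first, only, known or untested is meant among the compounds shown, and "the series" means these compounds.

Measured so far:

Compound 1, `CN(/N=N/c1ccccc1)c1ccccc1`. In an ADME assay on MDBK cells (Bos taurus) for cytotoxicity, read by MTT assay, with a stated time of 96 h (on this read-out higher numbers stand for lower toxicity in this test and lower numbers for higher toxicity in this test), compound 1 gives > 100000 nM, which is a limit of the assay and not a number.

Compound 2, `FC(F)(F)c1cccc(/N=N/N2CCCC2)c1`. In this assay compound 2 gives > 100000 nM, likewise a limit of the assay.

Compound 1 therefore stands nowhere above or below anything measured: both values shown are limits, as the limit of > 100000 nM in this assay, at which 2 of the 2 values shown sit, records, and no ordering between compound 1 and compound 2 can be drawn from them.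

Compound 3, `Cc1ccc(/N=N/N(C)c2ccccc2)cc1`, is not yet measured. It differs from compound 1 by methyl in place of hydrogen on an aromatic carbon.

Within the data shown here, no step between measured compounds is available for this assay. Given that compound 1 sits at the limit, the step from compound 1 to compound 3 is expected to be none beyond the scatter, that is a step that the limit leaves unreadable from compound 1 to compound 3, and compound 3 is expected most likely to be reported again only as a limit.

For compound 3 the estimate in this assay is 150000 nM, with a range of 50000 nM to 500000 nM.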

Compound 3, half-maximal cytotoxic concentration: > 100000 nM
Compound 3: only a limit was reported; the forecaster's own chance of this, stated with the estimate: 80%; the middle value lies beyond the limit too.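

Among these compounds, no step from compound 1 to compound 3 can be read in this assay, as both compounds are reported only as limits. The compounds shown leave open where any of them would give a measured cytotoxic concentration, and whether methyl in place of hydrogen on an aromatic carbon alters it.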